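A Smaller Group on the Shared Core

The source may hold more compounds than are shown below. What is called first, only, known or untested is meant among the compounds shown, and "the series" means these compounds.

Compound 1 `CC(C)(C)c1cn(C[C@H](O)[C@H]2OC(=O)C(OCc3ccccc3)=C2OCc2ccccc2)nn1`: 29200 nM
Compound 2 `O=C1O[C@H]([C@@H](O)Cn2cc(CNS(=O)(=O)c3ccc(Cl)cc3F)nn2)C(OCc2ccccc2)=C1OCc1ccccc1`: 25500 nM
Compound 3 `O=C1O[C@H]([C@@H](O)Cn2cc(CNS(=O)(=O)c3ccc(F)cc3)nn2)C(OCc2ccccc2)=C1OCc1ccccc1`: 18300 nM

All three measured compounds share one core and differ only in the group carried on an aromatic carbon of a five-membered aromatic ring with 3 nitrogen. In a functional assay on HepG2 cells (Homo sapiens) for antiproliferative activity, read by MTT assay, with a stated time of 72 h (on this read-out lower numbers stand for stronger inhibition and higher numbers for weaker inhibition), compound 3 gives 18300 nM, the lowest of the three numbers, yet neither neighbour is separated from it beyond the scatter: a 1.4-fold lower number from compound 2 to compound 3 (0.14 log units; within the scatter) and a 1.6-fold lower number from compound 1 to compound 3 (0.20 log units; within the scatter). Compound 4 `O=C1O[C@H]([C@@H](O)Cn2cc(C3CC3)nn2)C(OCc2ccccc2)=C1OCc1ccccc1` differs from compound 3 by cyclopropyl in place of (((4-fluorophenyl)sulfonyl)amino)methyl on an aromatic carbon. The step from compound 1 to compound 3 bears on this change most directly, since there a carbon-only group (tert-butyl) was exchanged for the same sulfonylamino-bearing group that now leaves, and the number barely moved. Cyclopropyl, like tert-butyl, brings no hydrogen-bond donor or acceptor, so the return to a small carbon-only group is expected to give a step of a 1.4-fold higher number from compound 3 to compound 4 (0.15 log units; within the scatter), not beyond the scatter. Compound 4 is therefore estimated at 26000 nM, with a range from 11000 nM to 60000 nM.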

Compound 4, half-maximal inhibitory concentration: 38100 nM
Beside the measured number, compound 4's estimate is 1.5-fold (0.17 log units) below it; the range from low to high includes it.
By their numbers in this assay, from the lowest: compounds 3, 2, 1 and 4 (each within the scatter of the next, the first and the last beyond it).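

In this assay this position now shows its first step beyond the scatter: a 2.1-fold higher number from compound 3 to compound 4 (0.32 log units; beyond the scatter) when cyclopropyl replaces (((4-fluorophenyl)sulfonyl)amino)methyl on the aromatic carbon, although the step is modest. The two carbon-only groups cannot be told apart, with a 1.3-fold higher number from compound 1 to compound 4 (0.12 log units; within the scatter) lying within the scatter, so tert-butyl and cyclopropyl give similar numbers here even though only compound 4 is separated from compound 3. No measurement shown explains the step from compound 3 to compound 4.

The large group leaves as a whole, so its aromatic ring, its sulfonyl and its amide-like hydrogen cannot be separated from one another. A plain phenyl or an aminomethyl group at this position would help show which part matters, and a carboxylic acid there remains an open question too.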